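Ethyl on the Amide Nitrogen of Compound 2

The compounds below may be only part of what the source reports. "The series", "measured", "known", "first", "only" and "open" are said of these compounds alone.

Compound 2 `NC(=O)c1cc(-c2ccc(NS(=O)(=O)c3cccc(Cl)c3Cl)cc2)nc2[nH]ncc12` carries a carbamoyl group on the shared core. In an assay for inhibition of serine/threonine-protein kinase Sgk1 (Homo sapiens), with stated times of 30 min and 60 min, in the presence of a further agent that is not named here (on this read-out lower numbers stand for stronger inhibition and higher numbers for weaker inhibition), compound 2 gives 1 nM. Among the measured compounds shown here, its only measured neighbour is compound 1 `CC(C)N1CC[C@H](NC(=O)c2cc(-c3ccc(NS(=O)(=O)c4cccc(Cl)c4Cl)cc3)nc3[nH]ncc23)C1`, which bears a 1-isopropylpyrrolidin-3-yl group on that amide-type nitrogen; in this assay compound 1 gives 4 nM. Of the two numbers, compound 2 holds the lower one, and the step of a 4.0-fold lower number from compound 1 to compound 2 (0.60 log units; beyond the scatter) lies beyond the scatter.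

Compound 3 `CCNC(=O)c1cc(-c2ccc(NS(=O)(=O)c3cccc(Cl)c3Cl)cc2)nc2[nH]ncc12` differs from compound 2 by ethyl in place of hydrogen on an amide-type nitrogen: amino becomes ethylamino, carbamoyl becomes ethylcarbamoyl, on an amide-type nitrogen whose other neighbour is the carbonyl carbon. For the measured compounds named here, the single measured step that bears on this change is the removal of the larger group from that nitrogen, a 4.0-fold lower number from compound 1 to compound 2 (0.60 log units; beyond the scatter), a modest change. Ethyl is a smaller group than the one that leaves in that step, so a smaller step in the opposite direction is expected, in this assay an expected 2.0-fold higher number from compound 2 to compound 3 (0.30 log units; within the scatter). Compound 3 is therefore expected to give about 2 nM in this assay, with a range from 0.7 nM to 6 nM.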

Compound 3, half-maximal inhibitory concentration: 6 nM
The estimate for compound 3 lay 3.0-fold (0.48 log units) below the measured number; the range from low to high includes it.
By their numbers in this assay, from the lowest: compound 2; then compounds 1 and 3 (each within the scatter of the next).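

At this position, on an amide-type nitrogen whose other neighbour is the carbonyl carbon, a group of only 2 carbon atoms is enough to raise the number in this assay: the step is a 6.0-fold higher number from compound 2 to compound 3 (0.78 log units; beyond the scatter), so the hydrogen of compound 2 is not matched by ethyl any more than by the 1-isopropylpyrrolidin-3-yl group. The size of the entering group does not order the results among these compounds, since exchanging the larger group for ethyl gives a 1.5-fold higher number from compound 1 to compound 3 (0.18 log units; within the scatter), which leaves the two substituted amides indistinguishable, and all three compounds fit the reading that the unsubstituted carbamoyl gives the lowest number. Nothing available accounts for why ethyl and the larger group land so close together, and no measurement bears on the cause of the step.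

Still open, going by these compounds, is whether a single methyl on the same nitrogen would already give the same rise as ethyl, or would stay with compound 2. Equally open, on these data alone, is how a longer chain, a hydroxyethyl group or a chain ending in a carboxylic acid would read in this assay.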